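This account rests on a few compounds, and the source may have more. Where it says the series, first, only, none or still open, it means among the compounds named here.

In a physicochemical assay for solubility, with a stated time of 18 h, at pH 7.4 (on this read-out higher numbers stand for higher solubility and lower numbers for lower solubility), the measured compounds are:

Compound 1 `COc1ccc(F)cc1CNCCCNc1ccnc2cc(Cc3cc(C)cc(C)c3)ccc12`: 4200 nM
Compound 2 `Cc1cc(C)cc(Cc2ccc3c(NCCCNCc4ccco4)ccnc3c2)c1`: 4200 nM
Compound 3 `COc1cccc(CNCCCNc2ccnc3cc(-c4ccccc4)ccc23)c1O`: 32000 nM

Compound 1 stands level with compound 2 at the digits shown, and together they give the lowest of the three numbers; compound 3 gives a higher number, but it differs from compound 1 in more than one place, so only its two values can be compared. For the measured compounds named here, the one single-point step measured here, no change at the digits printed from compound 1 to compound 2 (within the scatter), replaces a group on a saturated chain carbon bound to an amine nitrogen, a different place from the one that changes in compound 4.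

Compound 4 `COc1ccc(F)cc1CNCCCNc1ccnc2cc(Cc3ccc(F)cc3Cl)ccc12` differs from compound 1 by 2-chloro-4-fluorophenyl in place of 3,5-dimethylphenyl on a saturated chain carbon bound to an aromatic carbon. Going by the values given here, no measured step alters this place, so no step size can be read across from the data; the only single-point step recorded lies within the scatter. Compound 4 is therefore expected to show no change beyond the scatter, a 1.1-fold higher number from compound 1 to compound 4 (0.03 log units; within the scatter). The estimate for compound 4 in this assay is 4500 nM, with a range from 1500 nM to 13000 nM.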

Compound 4, solubility: 4200 nM
The estimate for compound 4 lay 1.1-fold (0.03 log units) above the measured number; the measured number falls inside the stated range.
By their numbers in this assay, from the lowest: compounds 1, 2 and 4 (each within the scatter of the next); then compound 3.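

In this assay, for the compounds shown here, the change from 3,5-dimethylbenzyl to 2-chloro-4-fluorobenzyl gives no change at the digits printed from compound 1 to compound 4 (within the scatter), the first reading at this place on a saturated chain carbon bound to an aromatic carbon. The exchange swaps two methyl groups for a fluorine and a chlorine on the ring, and this read-out stays within the scatter. With the step at the other end of the molecule, both single-place steps now shown lie within the scatter, and nothing available bears on why these numbers stay together.

As far as these compounds go, it remains open whether this place would respond to a group of a different kind, such as a phenyl ring carrying a carboxylic acid or an amine, or a pyridine ring. A longer chain in place of the single saturated carbon is equally untested by these compounds.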